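A Methyl Group Added to the Core and Cell Cytotoxicity

A few compounds are considered here, and "the series" means these few. Any claim that something is new, unique, unknown or untested is made for them only; others in the source may bear on it.

Compound 1 `COC(=O)c1sc2nc(C)ccc2c1Nc1cc(OC)c(OC)c(OC)c1` and compound 2 `COC(=O)c1sc2ncccc2c1Nc1cc(OC)c(OC)c(OC)c1` share one core, while compound 3 `COC(=O)c1sc2ccccc2c1Nc1cc(OC)c(OC)c(OC)c1` has a different core; the difference between the two cores is not broken down here. In a functional assay on A549 cells (Homo sapiens) for cytotoxicity, read by MTT assay, with a stated time of 72 h (on this read-out higher numbers stand for weaker inhibition and lower numbers for stronger inhibition), compound 1 gives 16.2 nM, compound 2 gives 3850 nM and compound 3 gives 2850 nM. The change from compound 2 to compound 1 is methyl in place of hydrogen on an aromatic carbon, and it made a 240-fold lower number from compound 2 to compound 1 (2.38 log units; beyond the scatter). Compound 4 `COC(=O)c1sc2cccc(C)c2c1Nc1cc(OC)c(OC)c(OC)c1`, not yet measured, carries the same kind of change on the core of compound 3: methyl in place of hydrogen on an aromatic carbon. The surroundings differ, though: in compound 1 the methyl sits on a six-membered aromatic ring with one nitrogen, next to the ring nitrogen, meta and para to a fused ring, whereas in compound 4 it sits on a six-membered ring of carbon only, ortho and meta to a fused ring. Because a 240-fold lower number from compound 2 to compound 1 (2.38 log units; beyond the scatter) was large, a clear drop is expected for compound 4, tempered by the changed place. The expected step is a 9.5-fold lower number from compound 3 to compound 4 (0.98 log units; beyond the scatter). Compound 4 is estimated at 300 nM, between 30 nM and 2500 nM.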

Compound 4, half-maximal inhibitory concentration: 4580 nM
Compound 4: middle estimate off by 15-fold (1.18 log units), on the low side; the whole stated range lies below it.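

In this assay, methyl in place of hydrogen on an aromatic carbon gave a 1.6-fold higher number from compound 3 to compound 4 (0.21 log units; within the scatter), so on the core of compound 3 this change brought no shift that can be told from the scatter. The effect seen on the core of compound 1 therefore did not carry over to the core of compound 3: the same change on two cores in this assay, a 240-fold lower number (2.38 log units; beyond the scatter) from compound 2 to compound 1 and a 1.6-fold higher number (0.21 log units; within the scatter) from compound 3 to compound 4, 380-fold (2.58 log units) apart, beyond the scatter of two such steps. The two pairs differ in both the core and the place of the methyl, and they cannot show which of these matters.

From the compounds shown here alone, it remains open whether a methyl at another place on the core of compound 3 would give a large step. Also open, going by these compounds, is whether an ethyl group or an amine in place of the methyl would keep the low number of compound 1.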